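This account rests on a few compounds, and the source may have more. Where it says the series, first, only, none or still open, it means among the compounds named here.

Measured compounds:
Compound 1, `CCCCCCCCNC(=O)[C@@H](NC(=O)c1nccc2ccccc12)[C@@H](C)O` — 66000 nM
Compound 2, `CCCCCCCCNC(=O)[C@@H](NC(=O)/C=C/c1ccccc1)[C@@H](C)O` — 41400 nM

In a functional assay on SiHa cells (Homo sapiens) for cytotoxicity, read by MTT assay, with a stated time of 48 h (a higher number here means a weaker inhibitor, a lower number a stronger inhibitor), compound 1 gives 66000 nM, the higher of the two numbers recorded. Compound 2 gives 41400 nM, and the gap between these two values lies within the scatter, so the two compounds cannot be set apart on this evidence.

Compound 3, `CCCCCCCCCCCCNC(=O)[C@@H](NC(=O)c1nccc2ccccc12)[C@@H](C)O`, is the next compound, not yet measured in this assay. It differs from compound 1 in one place: butyl in place of hydrogen on a saturated chain carbon, eight bonds along the chain from an amide-type nitrogen. The shared core and the rest of the molecule are kept.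

Among the compounds with values here, no step of this kind has been measured among the compounds available, so the expectation rests only on the structural change itself. A modest step is expected from compound 1 to compound 3, toward a lower number, though a step no larger than the scatter would not be surprising. Compound 3 is therefore estimated at 30000 nM, with a range from 8000 nM to 120000 nM, corresponding to an expected step of a 2.2-fold lower number from compound 1 to compound 3 (0.34 log units; beyond the scatter).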

Compound 3, half-maximal inhibitory concentration: 56600 nM
Beside the measured number, compound 3's estimate is 1.9-fold (0.28 log units) below it; the range from low to high includes it.
By their numbers in this assay, from the lowest: compounds 2, 3 and 1 (each within the scatter of the next).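

Within the data shown here, the first one-place step at this position, butyl in place of hydrogen on a saturated chain carbon, eight bonds along the chain from an amide-type nitrogen, is a 1.2-fold lower number from compound 1 to compound 3 (0.07 log units; within the scatter) in this assay. Adding these four carbons therefore gives no readable change, and compound 1 and compound 3 cannot be set apart on this evidence. Nothing available offers a reason for this result.

From the compounds shown here alone, whether a longer chain, an amine or a carboxylic acid in place of butyl at this position would give a step beyond the scatter remains open. Going by these compounds, it is also open whether the same butyl change would give a similar step on compound 2, since this single step comes from one pair on one shared core.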